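This account rests on a few compounds, and the source may have more. Where it says the series, first, only, none or still open, it means among the compounds named here.

Working notes on the furan-amide series.

Two compounds have numbers in an assay on cytosol from placenta for inhibition of 17-beta-hydroxysteroid dehydrogenase type 1 (Homo sapiens), read by HPLC, with a stated time of 10 min, in the presence of a further agent that is not named here (on this read-out higher numbers stand for weaker inhibition and lower numbers for stronger inhibition), so far. Compound 1 `Cc1ccccc1N(C)C(=O)c1ccc(-c2ccccc2O)o1` gives 1900 nM in this assay. Compound 2 `Cc1cccc(F)c1N(C)C(=O)c1ccc(-c2ccc(O)cc2)o1` gives 310 nM in this assay. Among the compounds with values here, of the two numbers, compound 2 holds the lower one, and the gap to compound 1 is beyond the usual scatter; the two structures differ in more than one place, so the pair shows only that compound 2 is the stronger inhibitor of the two, not which part of the difference carries the effect.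

Compound 3 `Cc1ccc(F)cc1N(C)C(=O)c1ccc(-c2ccc(O)cc2)o1` has not yet been measured in this assay. Relative to compound 2 it carries 5-fluoro-2-methylphenyl in place of 2-fluoro-6-methylphenyl on an amide-type nitrogen; the atoms are the same, only joined differently. Within the data shown here, no single-change step between measured compounds is available to set the size of such a rearrangement, so the expectation rests on compound 2 alone. The estimated step from compound 2 to compound 3 is a 1.6-fold higher number from compound 2 to compound 3 (0.21 log units; within the scatter), a modest weakening that may still fall inside the scatter. Compound 3 is therefore expected to give about 500 nM in this assay, estimated within a range from 150 nM to 1600 nM.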

Compound 3, half-maximal inhibitory concentration: 41 nM
Compound 3: the middle estimate sits 12-fold (1.09 log units) above what was measured; measured number below the stated range.
By their numbers in this assay, from the lowest: compound 3; then compound 2; then compound 1.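

Within the data shown here, on an amide-type nitrogen, 5-fluoro-2-methylphenyl in place of 2-fluoro-6-methylphenyl gives a 7.6-fold lower number from compound 2 to compound 3 (0.88 log units; beyond the scatter) in this assay, a step beyond the scatter and the first single-change step. Compound 2 and compound 3 have the same atoms, joined differently, so the way the fluorine and methyl are arranged on this aryl group is enough by itself to shift the number, something the pair of compound 1 and compound 2 could not isolate. No measurement at hand accounts for the size or direction of this step, so it stands as an observation only.

The compounds shown leave open what each substituent contributes, since neither a chlorine or methoxy group in place of the fluorine nor a version of this aryl group carrying only the methyl appears with the rest of compound 3 held fixed. They also leave open whether the same rearrangement would give a step of similar size on the core of compound 1.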